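Compound 4: Shifting One Fluorine on the Benzyl Arm

The source may report more compounds than this note shows. Statements on the series, on what has been measured and on what is new or still open speak of the compounds shown alone.

Measured so far in an assay for inhibition of high affinity nerve growth factor receptor (Homo sapiens), read by HTRF, with a stated time of 30 min, in the presence of a further agent that is not named here; a higher number here means a weaker inhibitor, a lower number a stronger inhibitor:
compound 1 `Cc1cc(Nc2nc(NCc3ccc(C#N)cc3)nc3ccccc23)n[nH]1`, 83 nM
compound 2 `Cc1cc(Nc2nc(NCc3ccccc3F)nc3ccccc23)n[nH]1`, 110 nM
compound 3 `Cc1cc(Nc2nc(NCc3ccc(F)cc3F)nc3ccccc23)n[nH]1`, 200 nM
Not yet measured: compound 4 `Cc1cc(Nc2nc(NCc3c(F)cccc3F)nc3ccccc23)n[nH]1`.

Compound 3 gives the highest number of the three in this assay. Its nearest neighbour is compound 2, as a 1.8-fold higher number from compound 2 to compound 3 (0.26 log units; within the scatter), a step that stays within the scatter; the step of a 2.4-fold higher number from compound 1 to compound 3 (0.38 log units; beyond the scatter) is the only one in the set that reaches beyond it, and it is modest.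

Compound 4 differs from compound 3 by a single rearrangement: 2,6-difluorophenyl in place of 2,4-difluorophenyl on a saturated chain carbon bound to a nitrogen on an aromatic ring. Among the measured compounds shown here, two measured steps touch this part of the molecule. The step of a 1.8-fold higher number from compound 2 to compound 3 (0.26 log units; within the scatter) shows that a fluoro in place of hydrogen on this ring moved the number by less than the scatter, and the step of a 1.3-fold higher number from compound 1 to compound 2 (0.12 log units; within the scatter) shows that exchanging the whole ring substituent pattern also stayed within it. For the measured compounds named here, no measured pair places a fluorine on both sides of the attachment, so compound 4 is estimated largely from how little this ring has mattered so far.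

Compound 4 is therefore expected to land close to compound 3, with an estimated step of a 1.1-fold lower number from compound 3 to compound 4 (0.02 log units; within the scatter), not clearly beyond the scatter in either direction. The estimate for compound 4 in this assay is 190 nM, with a range from 85 nM to 450 nM.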

Compound 4, half-maximal inhibitory concentration: 160 nM
Compound 4: the middle estimate sits 1.2-fold (0.07 log units) above what was measured, and the stated range covers the measured number.
By their numbers in this assay, from the lowest: compounds 1, 2, 4 and 3 (each within the scatter of the next, the first and the last beyond it).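

In this assay, among the compounds shown here, the change from 2,4-difluorobenzyl to 2,6-difluorobenzyl gives the first pair with the same atoms joined differently, and a 1.3-fold lower number from compound 3 to compound 4 (0.10 log units; within the scatter) shows no clear effect of where the second fluorine sits on this ring. Adding that fluorine to compound 2 in the 2,6-difluorophenyl arrangement gives a 1.5-fold higher number from compound 2 to compound 4 (0.16 log units; within the scatter) and replacing 4-cyanophenyl gives a 1.9-fold higher number from compound 1 to compound 4 (0.29 log units; within the scatter) so both steps stay within the scatter, unlike the step from 4-cyanophenyl to 2,4-difluorophenyl, a 2.4-fold higher number from compound 1 to compound 3 (0.38 log units; beyond the scatter) which is the only one in the set that goes beyond it. No supporting measurement is available to account for these small differences.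

From the compounds shown here alone, all four compounds carry only fluoro or cyano substituents on this ring, so it remains open whether an amine, a carboxylic acid or a methoxy group there would move the number beyond the scatter. A longer chain in place of the benzyl link, and any change to the shared core, are equally untested by the compounds shown here.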